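Cytotoxicity Limits Across Three Amine-Linked Analogues

The compounds below may be only part of what the source reports. "The series", "measured", "known", "first", "only" and "open" are said of these compounds alone.

Measured compounds:
compound 1 `Cc1ccc2cc(CN(Cc3ccc(F)cc3)Cc3ccc(C(F)(F)F)cc3)c(=O)[nH]c2c1`: > 33000 nM
compound 2 `Cc1ccc2[nH]c(=O)c(CN(Cc3ccc(F)cc3)Cc3ccc(-c4ccccc4)cc3)cc2c1`: > 5000 nM
compound 3 `CCCOc1ccc(CN(Cc2ccc(C(C)(C)C)cc2)Cc2cc3cc(C)ccc3[nH]c2=O)cc1`: > 5000 nM

All three compounds were tested in a toxicity assay on MDCK cells (Canis lupus familiaris) for cytotoxicity, read by crystal violet staining, with a stated time of 48 h; a higher number here means that more compound is tolerated, a lower number that less compound is tolerated. In this assay compound 1 reached only a limit, > 33000 nM, rather than a number. Compound 2 likewise reached only a limit, > 5000 nM. Compound 3 also reached only a limit, > 5000 nM, so no exact concentration is known for it. Compound 3 therefore stands at the limit of > 5000 nM in this assay, at which 2 of the 3 values shown sit, while the remaining value sits at the limit of > 33000 nM in this assay, at which 1 of the 3 values shown sits. Every value shown is a limit. Among the compounds with values here, no step between two measured compounds can be sized, and no ordering among them can be claimed.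

Compound 4 `COc1ccc(C(C)N(Cc2ccc(C(C)(C)C)cc2)Cc2cc3cc(C)ccc3[nH]c2=O)cc1` differs from compound 3 in one place: 1-(4-methoxyphenyl)ethyl in place of 4-propoxybenzyl on an amine nitrogen. Nothing measured here bears on this change, so for this assay the expected step is none beyond the scatter, and the most likely outcome is again a limit rather than a number. On that basis the estimate for compound 4 is 20000 nM, with a range from 5000 nM to 80000 nM, which means an expected step that the limit leaves unreadable from compound 3 to compound 4.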

Compound 4, half-maximal cytotoxic concentration: > 5000 nM
Compound 4 gave a limit, no number; the forecaster's own chance of this, stated with the estimate: 80%; the middle value does not contradict the limit.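

In this assay, compound 3 and compound 4 both end at a limit rather than a number, so the step from 4-propoxybenzyl to 1-(4-methoxyphenyl)ethyl on the amine nitrogen cannot be read. The compounds shown leave open the concentration at which any of them becomes toxic to the cells, and whether changing these groups alters it.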